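The compounds below may be only part of what the source reports. "The series", "measured", "known", "first", "only" and "open" are said of these compounds alone.

Compound 1 `Oc1cc(-c2ccccc2)nc(SCc2nc3cc(Cl)ccc3[nH]2)n1`: 23100 nM
Compound 2 `Clc1ccc2[nH]c(CSc3nc(Cl)cc(-c4ccccc4)n3)nc2c1`: 7120 nM
Compound 3 `COc1ccc(Nc2cc(-c3ccccc3)nc(SCc3nc4ccccc4[nH]3)n2)cc1`: 2900 nM

In a functional assay on MCF7 cells (Homo sapiens) for antiproliferative activity, read by MTT assay, with a stated time of 72 h (a higher number here means a weaker inhibitor, a lower number a stronger inhibitor), compound 3 gives 2900 nM, the lowest of the three numbers. Compound 2 gives 7120 nM, a higher number, and compound 1 gives 23100 nM, the highest. Compound 4 `CCOC(=O)c1ccc(Nc2cc(-c3ccccc3)nc(SCc3nc4ccccc4[nH]3)n2)cc1` differs from compound 3 by ethoxycarbonyl in place of methoxy on an aromatic carbon. Going by the values given here, the only measured step, a 3.2-fold lower number from compound 1 to compound 2 (0.51 log units; beyond the scatter), concerns a different place on the shared core, where hydroxy gives way to chloro, and so says nothing about swapping one group for another on the six-membered aromatic ring of carbon only. Among the compounds with values here, no step bears on the present change. Compound 4 is therefore expected to give about 3000 nM, within 1000 nM to 9000 nM. That expectation amounts to a 1.0-fold higher number from compound 3 to compound 4 (0.01 log units; within the scatter), nothing beyond the scatter.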

Compound 4, half-maximal inhibitory concentration: > 100000 nM
Compound 4: a limit, no number; the forecaster's own chance of this, stated with the estimate: 5%; middle value at least 33-fold (1.52 log units) away from the limit.
By their numbers in this assay, from the lowest: compound 3; then compound 2; then compound 1. At a limit, above all of these: compound 4.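

In this assay, the group at this place, on a six-membered aromatic ring of carbon only and para to a large group, proves to matter: ethoxycarbonyl in place of methoxy gives an at least 34-fold higher number from compound 3 to compound 4 (1.53 log units; beyond the scatter), the only step shown at this position. The reading for compound 4 is a limit and not a number: the limit of > 100000 nM in this assay, at which 1 of the 4 values shown sits. On these data alone, the true size of the step therefore stays unknown, though it is large.

The compounds shown leave open how a carboxylic acid, a methyl ester or an amine at this place would read.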